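This account rests on a few compounds, and the source may have more. Where it says the series, first, only, none or still open, it means among the compounds named here.

Measured in an assay on CHO cells for displacement of a labelled ligand from adenosine receptor A3 (Homo sapiens), read by scintillation counting, with a stated time of 45 min, in the presence of a further agent that is not named here; on this read-out higher numbers stand for weaker inhibition and lower numbers for stronger inhibition:
compound 1 `CCCn1c(=O)[nH]c2nc(-c3ccc(S(=O)(=O)N4CCN(c5cccc(Cl)c5)CC4)cc3)[nH]c2c1=O` — 53.5 nM
compound 2 `CCCn1c(=O)[nH]c2nc(-c3ccc(S(=O)(=O)N4CCN(C(C)c5ccccc5)CC4)cc3)[nH]c2c1=O` — > 1000 nM
compound 3 `CCCn1c(=O)[nH]c2nc(-c3ccc(S(=O)(=O)N4CCN(c5ccc(I)cc5)CC4)cc3)[nH]c2c1=O` — > 1000 nM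

Compound 3 sits at the limit of this assay, and its value is not a number. Its standing is therefore fixed only by the step of an at least 18-fold higher number from compound 1 to compound 3 (1.27 log units; beyond the scatter). Compound 4 `CCCn1c(=O)[nH]c2nc(-c3ccc(S(=O)(=O)N4CCN(Cc5ccc(Br)cc5)CC4)cc3)[nH]c2c1=O` has not been measured; it differs from compound 3 by 4-bromobenzyl in place of 4-iodophenyl on an amine nitrogen in a ring. Within the data shown here, the steps that bear on this change are an at least 18-fold higher number from compound 1 to compound 3 (1.27 log units; beyond the scatter) and an at least 18-fold higher number from compound 1 to compound 2 (1.27 log units; beyond the scatter), both large losses on leaving 3-chlorophenyl; the pair of compounds 2 and 3 gives a step that the two limits leave unreadable from compound 2 to compound 3, so the two limits show no order between them (the limit of > 1000 nM in this assay, at which 2 of the 3 values shown sit). For compound 4 a number near the limit is expected, a step that the limit leaves unreadable from compound 3 to compound 4, with the estimate 1500 nM spanning 400 nM to 6000 nM.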

Compound 4, inhibition constant: > 1000 nM
Compound 4: a limit, no number; the forecaster's own chance of this, stated with the estimate: 60%; the middle value is on the limit's open side.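

At this place, on an amine nitrogen in a ring, 4-bromobenzyl is a third group in place of 3-chlorophenyl that gives an at least 18-fold higher number from compound 1 to compound 4 (1.27 log units; beyond the scatter). The value of compound 4 in this assay is a limit, and the steps among compound 2, compound 3 and compound 4 cannot be read, so no order among these three groups can be given. Only compound 1 gives a number here, and the others stand at a limit: the limit of > 1000 nM in this assay, at which 3 of the 4 values shown sit.

Still open, as far as these compounds go, is whether 3-chlorobenzyl, 3-bromophenyl, 4-chlorophenyl or unsubstituted phenyl on this nitrogen would give a number rather than a limit.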